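Compound 4 after the halogenated limit compounds

A few compounds are considered here, and "the series" means these few. Any claim that something is new, unique, unknown or untested is made for them only; others in the source may bear on it.

Measured in a functional assay on Jurkat cells (Homo sapiens) for antiproliferative activity, read by MTT assay, with a stated time of 72 h; on this read-out lower numbers stand for stronger inhibition and higher numbers for weaker inhibition:
- Compound 1 `COc1cc(-n2ncnc2-c2ccc(C)cc2)cc(OC)c1OC`: 300 nM
- Compound 2 `COc1cc(-n2ncnc2-c2cccc(Cl)c2)cc(OC)c1OC`: > 10000 nM (a limit)
- Compound 3 `COc1cc(-n2ncnc2-c2cccc(F)c2)cc(OC)c1OC`: > 10000 nM (a limit)

Compound 3 has no number, only the limit > 10000 nM. This is the limit of > 10000 nM in this assay, at which 2 of the 3 values shown sit, so it cannot be placed more exactly in this assay.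

The next structure is compound 4 `COc1ccccc1-c1ncnn1-c1cc(OC)c(OC)c(OC)c1`, with 2-methoxyphenyl in place of 3-fluorophenyl on an aromatic carbon.

For the measured compounds named here, two measured steps bear on this change, both large and beyond the scatter: an at least 33-fold higher number from compound 1 to compound 2 (1.52 log units; beyond the scatter) and an at least 33-fold higher number from compound 1 to compound 3 (1.52 log units; beyond the scatter). Both remove 4-methylphenyl, which compound 4 also lacks. The third step, a step that the two limits leave unreadable from compound 2 to compound 3, gives no size. Going by the values given here, no measured compound carries 2-methoxyphenyl, so the direction rests on little.

A reading near the limit is expected, with at most a modest move towards a lower number. The expected change is an at least 2.0-fold lower number from compound 3 to compound 4 (0.30 log units; that floor lies within the scatter). For compound 4 the estimated value is 5000 nM, with an expected range of 800 nM to 10000 nM.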

Compound 4, half-maximal inhibitory concentration: > 10000 nM
Compound 4 ended at the assay's limit; the forecaster's own chance of this, stated with the estimate: 55%; middle value at least 2.0-fold (0.30 log units) from the limit.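

In this assay compound 4 gives > 10000 nM, which is a limit and not a number. For the compounds shown here, on the aromatic carbon between two ring nitrogen atoms, 2-methoxyphenyl in place of 4-methylphenyl gives an at least 33-fold higher number from compound 1 to compound 4 (1.52 log units; beyond the scatter), so the loss seen with the 3-chlorophenyl and 3-fluorophenyl compounds also appears with a ring carrying no halogen, and compound 1 remains the only compound with a readable value: the limit of > 10000 nM in this assay, at which 3 of the 4 values shown sit. The steps among compound 2, compound 3 and compound 4 cannot be read, so no order among these three can be given.

The compounds shown leave open whether the readable value of compound 1 depends on the methyl group itself or on where it sits on the phenyl ring. Also open, from the compounds shown here alone, is how this assay would read with an amine or a longer chain in place of that methyl group.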